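Benzyl for methyl on selenium: outlook for compound 4

The source may hold more compounds than are shown below. What is called first, only, known or untested is meant among the compounds shown, and "the series" means these compounds.

The series holds three measured compounds and one awaiting measurement. In a functional assay on HT-29 cells (Homo sapiens) for cytotoxicity, read by MTT assay, with a stated time of 72 h (on this read-out lower numbers stand for stronger inhibition of growth and higher numbers for weaker inhibition of growth), compound 1 `CS/C(=N\C(=O)c1cc(-c2ccccc2)nc2ccccc12)NC(=O)c1cc(-c2ccccc2)nc2ccccc12` gives 23700 nM, compound 3 `C[Se]/C(=N\C(=O)c1cnc2ccccc2c1)NC(=O)c1cnc2ccccc2c1` gives 200 nM, and compound 2 `C[Se]/C(=N\C(=O)c1ccco1)NC(=O)c1ccco1` gives 0.05 nM. Compound 2 stands at the lowest number of the three; its gaps to compound 3 and to compound 1 both lie beyond the scatter, so compound 2 is the strongest inhibitor of growth in the measured set.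

Compound 4 `O=C(/N=C(/NC(=O)c1ccco1)[Se]Cc1ccccc1)c1ccco1` keeps the core of compound 2 and differs in one place: phenyl in place of hydrogen on a saturated chain carbon bound to a selenium atom. Cut one bond further out, the same difference reads methyl to benzyl. For the measured compounds named here, no measured pair shows this change, so its effect in this assay can only be estimated. Since compound 2 sits at 0.05 nM, far below the other two numbers, the expectation is a move toward a higher number, beyond the scatter, with wide uncertainty. The expected step is a 40-fold higher number from compound 2 to compound 4 (1.60 log units; beyond the scatter). Compound 4 is estimated at 2 nM, within a range of 0.1 nM to 100 nM in this assay.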

Compound 4, concentration for 50% growth inhibition: 7190 nM
Estimate against measurement, compound 4: 3600-fold (3.56 log units) below, and the stated range ends below it.
By their numbers in this assay, from the lowest: compound 2; then compound 3; then compound 4; then compound 1.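

Phenyl in place of hydrogen on a saturated chain carbon bound to a selenium atom is the first change in the series that can be read at a single place. In this assay the step is a 140000-fold higher number from compound 2 to compound 4 (5.16 log units; beyond the scatter) and it lies well beyond the scatter, so what sits on selenium has a large bearing on growth inhibition even with the rest of compound 2 unchanged. Nothing available explains the size of this loss.

On these data alone, with one step at this place, it remains open whether the loss grows gradually with the group or appears only with the aromatic ring. An ethyl or propyl chain on selenium, or an amine or a carboxylic acid carried on that chain, could place a compound anywhere from compound 2 to compound 4.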